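Moving the Fluorine in Compound 1

The source may report more compounds than this note shows. Statements on the series, on what has been measured and on what is new or still open speak of the compounds shown alone.

Measured in a functional assay on MCF7 cells (Homo sapiens) for antiproliferative activity, read by MTT assay, with a stated time of 48 h (a lower number here means a stronger inhibitor, a higher number a weaker inhibitor), so far
Compound 1 `N=C(N)N/N=C(/C=C/c1ccc(F)cc1)c1ccccc1` gives 2500 nM
Compound 2 `N=C(N)N/N=C(/C=C/c1ccc(OCc2ccccc2)cc1)c1ccccc1` gives 1200 nM
Compound 3 `N=C(N)N/N=C(/C=C/c1cccc([N+](=O)[O-])c1)c1ccccc1` gives 6500 nM

Compound 1 stands in the middle of these three numbers, with a lower number for compound 2 and a higher number for compound 3. Both gaps lie beyond the usual scatter of repeated measurements.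

Compound 4 `N=C(N)N/N=C(/C=C/c1ccccc1F)c1ccccc1` has not yet been measured. It keeps the core of compound 1 but carries 2-fluorophenyl in place of 4-fluorophenyl on a double-bonded chain carbon bound to a double-bonded chain carbon. The change is 2-fluorophenyl in place of 4-fluorophenyl on a double-bonded chain carbon bound to a double-bonded chain carbon and the two compounds have the same atoms, joined differently.

Among the compounds with values here, only one measured step starts from compound 1, and it is a 2.1-fold lower number from compound 1 to compound 2 (0.32 log units; beyond the scatter) in a modest move. That step puts benzyloxy in place of fluoro on an aromatic carbon, so it swaps the group and does not relocate it. Within the data shown here, no measured pair shows what relocating the fluorine does, so the data offer only weak guidance and no clear direction. An expected step of a 1.2-fold higher number from compound 1 to compound 4 (0.08 log units; within the scatter) is therefore the working figure, with no change beyond the scatter anticipated. For compound 4 the estimated value is 3000 nM with an expected range from 1200 nM to 7000 nM in this assay as the test.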

Compound 4, half-maximal inhibitory concentration: 3900 nM
Beside the measured number, compound 4's estimate is 1.3-fold (0.11 log units) below it; the range from low to high includes it.
By their numbers in this assay, from the lowest: compound 2; then compounds 1, 4 and 3 (each within the scatter of the next, the first and the last beyond it).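

In this assay, moving the fluorine gives a 1.6-fold higher number from compound 1 to compound 4 (0.19 log units; within the scatter), so at this place on a double-bonded chain carbon bound to a double-bonded chain carbon, 2-fluorophenyl and 4-fluorophenyl cannot be told apart by this measurement. The earlier pair could not show this: a 2.1-fold lower number from compound 1 to compound 2 (0.32 log units; beyond the scatter) came from exchanging one group for a different one, whereas compounds 1 and 4 have the same atoms, joined differently, and that rearrangement alone produces no difference beyond the usual scatter. Nothing available here explains why the two compounds give such similar results.

The compounds shown leave open whether this holds only for fluorine or also for other groups, such as 2-chlorophenyl or 2-methoxyphenyl, at the same place. Within the data shown here, they also leave open whether a benzyloxy group, the one change from compound 1 that gives a step beyond the scatter, would keep that step if rearranged in the way the fluorine is in compound 4, and what an amine or a carboxylic acid on the same aromatic ring would do.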